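Swapping a Sugar for Fluorophenyl on the Ring Nitrogen

The compounds below may be only part of what the source reports. "The series", "measured", "known", "first", "only" and "open" are said of these compounds alone.

Three compounds share one core and differ only in the group attached to an aromatic nitrogen. In a functional assay on cells for antagonist activity at Gonadotropin-releasing hormone receptor (Homo sapiens), read by FLIPR and calcium flux, with a stated time of 15 min (a higher number here means a weaker inhibitor, a lower number a stronger inhibitor), compound 1 `C#CCN1CCN(c2cccc3[nH]c(-c4ccc(C(C)(C)C)cc4)nc23)CC1` gives 395 nM. In this assay compound 2 `CC(C)(C)OC(=O)N[C@@H](Cn1cc(CN2CCN(c3cccc4[nH]c(-c5ccc(C(C)(C)C)cc5)nc34)CC2)nn1)C(=O)O` gives 186 nM. These two numbers lie within the usual scatter of each other. Compound 3 `CC(C)(C)c1ccc(-c2nc3c(N4CCN(Cc5cn([C@@H]6O[C@H](CO)[C@@H](O)[C@H](O)[C@H]6O)nn5)CC4)cccc3[nH]2)cc1` carries a far more polar group on that nitrogen. For compound 3 the result in this assay is only a limit, > 1000 nM, not a number. Compound 3 therefore stands at the limit of > 1000 nM in this assay, at which 1 of the 3 values shown sits.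

Compound 4 `CC(C)(C)c1ccc(-c2nc3c(N4CCN(Cc5cn(-c6ccc(F)cc6)nn5)CC4)cccc3[nH]2)cc1` has not yet been tested. It differs from compound 3 by 4-fluorophenyl in place of 3,4,5-trihydroxy-6-(hydroxymethyl)oxan-2-yl on an aromatic nitrogen. Because compound 1 gives 395 nM and compound 2 gives 186 nM in this assay, a return to a measurable number is expected for compound 4. The step from compound 3 to compound 4 is expected to be an at least 3.3-fold lower number from compound 3 to compound 4 (0.52 log units; beyond the scatter), toward stronger inhibition. Compound 4 is expected to give 300 nM, with a range from 100 nM to 1000 nM.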

Compound 4, inhibition constant: 410 nM
Beside the measured number, compound 4's estimate is 1.4-fold (0.14 log units) below it, and the stated range covers the measured number.
By their numbers in this assay, from the lowest: compound 2; then compounds 1 and 4 (each within the scatter of the next). At a limit, above all of these: compound 3.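

Only compound 3 stands at a limit and not at a number: the limit of > 1000 nM in this assay, at which 1 of the 4 values shown sits. In this assay, placing 4-fluorophenyl on the aromatic nitrogen in place of 3,4,5-trihydroxy-6-(hydroxymethyl)oxan-2-yl gives an at least 2.4-fold lower number from compound 3 to compound 4 (0.38 log units; beyond the scatter), so this position can hold a flat carbon ring with no hydrogen-bond donors and still give a measurable number. Exchanging ethynyl for the whole 1-(4-fluorophenyl)-1H-1,2,3-triazol-4-yl group gives a 1.0-fold higher number from compound 1 to compound 4 (0.02 log units; within the scatter), so these two compounds cannot be told apart, and the added group brings no measurable change.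

As far as these compounds go, the full size of the step from the sugar group remains unknown, since one end of it is only a limit. A plain phenyl, a benzyl or a simple aminoethyl chain on that nitrogen would show whether the fluorine or the aromatic ring matters here.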